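Ester to oxime ether on the piperazine side chain

A few compounds are considered here, and "the series" means these few. Any claim that something is new, unique, unknown or untested is made for them only; others in the source may bear on it.

Working notes on a quinolone-acid series sharing one core. Compound 1 `COC(=O)CN1CCN(c2c(F)cc3c(=O)c(C(=O)O)cn(C4CC4)c3c2OC)CC1C` carries a (methoxycarbonyl)methyl group on the ring amine nitrogen; in an ADME assay on Vero cells (Chlorocebus sabaeus) for cytotoxicity, read by MTT assay, with a stated time of 72 h (a higher number here means that more compound is tolerated, a lower number that less compound is tolerated), compound 1 gives 500 ug/mL, so the series tolerates a great deal of compound in this cell-based read-out. Going by these compounds, compound 2 `CCOC(=O)CCN1CCN(c2c(F)cc3c(=O)c(C(=O)O)cn(C4CC4)c3c2OC)CC1C` carries the homologous ethyl ester chain; in this assay compound 2 gives "not determined" (no result reported), so its position on this scale is unknown and only compound 1 anchors the series.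

Compound 3 `CCO/N=C(\C)CN1CCN(c2c(F)cc3c(=O)c(C(=O)O)cn(C4CC4)c3c2OC)CC1C` is the next member. Its relation to compound 2: a group of 6 heavy atoms (4 carbon, 1 nitrogen, 1 oxygen; no ring) in place of a group of 6 heavy atoms (4 carbon, 2 oxygen; no ring), on a saturated chain carbon bound to an amine nitrogen in a ring. The change keeps the same count of heavy atoms and of hydrogen-bond acceptors on the side chain, so no step beyond the usual scatter is expected in this assay in either direction from the level that compound 1 sets.

On that basis, compound 3 is expected to give about 400 ug/mL in this assay, with a plausible range from 150 ug/mL to 800 ug/mL.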

Compound 3, half-maximal cytotoxic concentration: 31.3 ug/mL
The estimate for compound 3 lay 13-fold (1.11 log units) above the measured number; measured number below the stated range.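

The step of a 16-fold lower number from compound 1 to compound 3 (1.20 log units; beyond the scatter) in this assay shows that the read-out is sensitive to the group on a saturated chain carbon bound to an amine nitrogen in a ring: the series is not uniformly tolerated at the level compound 1 sets, and the (methoxycarbonyl)methyl group and the oxime ether chain of compound 3 are far from interchangeable here. Within the data shown here, compound 2 has no reported result, so the comparison between the (ethoxycarbonyl)methyl group and the oxime ether, the one change with matching heavy-atom counts, cannot be read, and the step from compound 1 combines a change of chain size with a change of functional group. Nothing at hand gives a measured basis for the step.

Going by these compounds, whether the lower number goes with the oxime ether itself or with the larger chain remains open, and a methyl oxime ether or a plain 2-oxopropyl chain in the same place would help separate the two. On these data alone, it is equally open whether an amide or a free carboxylic acid on this chain would stay near compound 1 or move toward compound 3.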